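Dithiocarbamate amine swap on the chromone series

The source may report more compounds than this note shows. Statements on the series, on what has been measured and on what is new or still open speak of the compounds shown alone.

Of the compounds shown here, two have numbers so far. Compound 1 `COc1ccc2occ(CSC(=S)N(C(C)C)C(C)C)c(=O)c2c1` carries a diisopropylamino group on its thiocarbonyl carbon; in a functional assay on SW480 cells (Homo sapiens) for antiproliferative activity, read by MTT assay, with a stated time of 72 h (a higher number here means a weaker inhibitor, a lower number a stronger inhibitor), compound 1 gives 4800 nM. Compound 2 `COc1ccc2oc(CSC(=S)N3CCCCC3)cc(=O)c2c1` has a different core and a piperidinyl group; in this assay compound 2 gives 2300 nM. Of the two numbers, that of compound 1 is the higher, and the gap to compound 2 lies beyond the usual scatter, so compound 1 is the weaker of the pair as measured.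

Compound 3 `COc1ccc2occ(CSC(=S)N3CCCC3)c(=O)c2c1` keeps the core of compound 1 and changes only the amine: pyrrolidin-1-yl in place of diisopropylamino on a thiocarbonyl carbon. Among the compounds with values here, no measured pair shows this exact change, so the size of the step is not known from the data. Within the data shown here, the only comparison available is that compound 2, which also carries a cyclic amine though on another core, gives 2300 nM, while compound 1 gives 4800 nM; of these two numbers, that of compound 2 is the lower. Accordingly compound 3 is expected to give 3000 nM in this assay, within a range of 1200 nM to 8000 nM. The expected step of a 1.6-fold lower number from compound 1 to compound 3 (0.20 log units; within the scatter) is a small drop, possibly not beyond the scatter.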

Compound 3, half-maximal inhibitory concentration: 4800 nM
For compound 3 the middle estimate is 1.6-fold (0.20 log units) below the measured one; measured number inside the range.
By their numbers in this assay, from the lowest: compound 2; then compounds 1 and 3 (each within the scatter of the next).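

Within the data shown here, on the core of compound 1, pyrrolidin-1-yl in place of diisopropylamino on a thiocarbonyl carbon gives no change at the digits printed from compound 1 to compound 3 (within the scatter) in this assay, and this is the first step in which the amine alone changes. Going from an open diisopropylamino group of 7 heavy atoms to a five-membered ring of 5 heavy atoms therefore does not separate the two compounds in this assay, so this pair gives no sign that the number at this position follows either ring closure or that difference in heavy atoms. No data on hand account for this result.

As far as these compounds go, compound 2 differs from compound 1 and from compound 3 in more than one place, so the separate contributions of its core and its piperidinyl group remain open. Also open, from the compounds shown here alone, is whether an amine of another kind on the shared core, such as morpholin-4-yl with its added ring oxygen, 4-methylpiperazin-1-yl or the smaller dimethylamino group, would move the number away from that of compound 1 by more than the scatter.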